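Adding methoxy to compound 1: the step to compound 3

The source may report more compounds than this note shows. Statements on the series, on what has been measured and on what is new or still open speak of the compounds shown alone.

Within the data shown here, in a functional assay on EA.hy 926 cells (Homo sapiens) for cytotoxicity, read by MTT assay, with stated times of 24 h and 12 h (a lower number here means that less compound is needed, a higher number that more compound is needed for the effect), compound 1 `Cc1nc(C)c(C(=O)Oc2ccccc2/C=C/C(=O)O)nc1C` gives 36700 nM, the lower of the two numbers so far, while compound 2 `COc1ccc(/C=C/C(=O)O)c(OC(=O)c2nc(C)c(C)nc2C)c1` gives 115000 nM. Compound 3 `COc1ccc(OC(=O)c2nc(C)c(C)nc2C)c(/C=C/C(=O)O)c1` is still unmeasured. Its difference from compound 1 is methoxy in place of hydrogen on an aromatic carbon, meta to a 2-carboxyethenyl group and para to a large group. Among the measured compounds shown here, only one measured step bears on this change: a 3.1-fold higher number from compound 1 to compound 2 (0.50 log units; beyond the scatter), a modest rise beyond the scatter for the same kind of replacement at another place on the ring. On these data alone, a single step is thin evidence, and the effect of the new place is unknown. A modest rise in this assay is therefore expected, with the estimated step being a 2.2-fold higher number from compound 1 to compound 3 (0.34 log units; beyond the scatter). For compound 3 the estimated value is 80000 nM, with an expected range of 30000 nM to 200000 nM.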

Compound 3, half-maximal effective concentration: 48600 nM
Compound 3: middle estimate off by 1.6-fold (0.22 log units), on the high side; the measured number falls inside the stated range.
By their numbers in this assay, from the lowest: compounds 1 and 3 (each within the scatter of the next); then compound 2.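

In this assay, methoxy in place of hydrogen on the aromatic carbon para to a large group gives a 1.3-fold higher number from compound 1 to compound 3 (0.12 log units; within the scatter) and so leaves no change that can be told from the scatter at this place. Among these compounds, the same replacement at the other place on the ring gives a 3.1-fold higher number from compound 1 to compound 2 (0.50 log units; beyond the scatter) and is the only one of these two steps beyond the scatter, so across compounds 2 and 3 the outcome of adding methoxy depends on where it stands. Nothing measured here speaks to why the two places differ.

On these data alone, whether a hydroxyl group, a fluorine atom or an amine at this place would also stay within the scatter remains open. Also open, as far as these compounds go, is whether a longer chain such as ethoxy would behave as methoxy does here.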